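A few compounds are considered here, and "the series" means these few. Any claim that something is new, unique, unknown or untested is made for them only; others in the source may bear on it.

Measured so far in a functional assay on MCF7 cells (Homo sapiens) for inhibition, read by sulforhodamine B assay, with a stated time of 72 h; a lower number here means a stronger inhibitor, a higher number a weaker inhibitor:
compound 1 `COc1cc(OC)c(C(=O)/C=C/c2cn(-c3ccccc3)nc2-c2ccsc2)c(OC)c1` — 2700 nM
compound 2 `O=C(/C=C/c1cn(-c2ccccc2)nc1-c1cccnc1)c1c[nH]c2ccccc12` — 2600 nM

Among the measured compounds shown here, compound 2 gives the lower of the two numbers in this assay, but the gap to compound 1 is within the scatter, so the two compounds read as equivalent; no step between them is computed, since they differ in more than one place.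

Compound 3 `COc1ccc(C(=O)/C=C/c2cn(-c3ccccc3)nc2-c2cccnc2)c(OC)c1` is not yet measured in this assay. It differs from compound 2 in one place: 2,4-dimethoxyphenyl in place of 1H-indol-3-yl on a carbonyl carbon. Compound 1, which carries a methoxy-substituted phenyl on the same carbonyl carbon, gives 2700 nM, which is close to compound 2, so the methoxyphenyl pattern on that carbonyl is not expected to shift the number far. The step from compound 2 to compound 3 in this assay is expected to be small, a 1.3-fold higher number from compound 2 to compound 3 (0.13 log units; within the scatter), at most slightly toward a weaker inhibitor, and not clearly beyond the scatter. Compound 3 is therefore expected to give about 3500 nM in this assay, in a range from 1200 nM to 10000 nM.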

Compound 3, half-maximal inhibitory concentration: 2300 nM
For compound 3 the middle estimate is 1.5-fold (0.18 log units) above the measured one; low and high end bracket the measured number.
By their numbers in this assay, from the lowest: compounds 3, 2 and 1 (each within the scatter of the next).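

In this assay, 2,4-dimethoxyphenyl in place of 1H-indol-3-yl on the carbonyl carbon gives a 1.1-fold lower number from compound 2 to compound 3 (0.05 log units; within the scatter) and so leaves the two compounds equivalent. With this exchange, the hydrogen-bond donor and the five-membered aromatic ring of the leaving group are gone and hydrogen-bond acceptors enter, yet the two numbers stay within the scatter, so for this pair neither the donor nor the five-membered ring is needed to hold the number at this position. No measurement is available that would account for this result.

Going by these compounds, whether a carboxylic acid, an amine or a longer chain on the same carbonyl carbon would move the number beyond the scatter remains open. Also open, on these data alone, is whether the equivalence of these two groups holds when the rest of the shared core changes.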